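Swapping an aromatic ring for neopentyl on compound 1

This account rests on a few compounds, and the source may have more. Where it says the series, first, only, none or still open, it means among the compounds named here.

In an ADME assay on liver for metabolic stability, with Liver microsome (Homo sapiens) as the target, read by LC-MS, using microsomes (on this read-out lower numbers stand for slow clearance and higher numbers for fast clearance), compound 1 (`Cc1cccc([C@@H](O)C(=O)N2N=CC[C@H]2C(=O)NCc2cc(Cl)ccc2-n2cnnn2)c1`) gives < 12 mL.min-1.g-1 as its result, which is a limit of the assay and not a number. Compound 1 thus stands at the limit of < 12 mL.min-1.g-1 in this assay, at which 1 of the 3 values shown sits, and has no exact place on the scale. The other two measured compounds give numbers: compound 2 (`CC(C)(C)OC[C@@H](O)C(=O)N1[C@H](C(=O)NCc2cc(Cl)ccc2-n2cnnn2)C[C@@H]2C[C@@H]21`) gives 21 mL.min-1.g-1 in this assay and compound 3 (`O=C([C@H](O)c1ccccc1)N1CC[C@@H]2C[C@@]21C(=O)NCc1cc(Cl)ccc1-n1cnnn1`) gives 43 mL.min-1.g-1 there.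

Compound 4 (`CC(C)(C)C[C@@H](O)C(=O)N1N=CC[C@H]1C(=O)NCc1cc(Cl)ccc1-n1cnnn1`) keeps the core of compound 1 but carries neopentyl in place of 3-methylphenyl on a saturated chain carbon bound to a carbonyl carbon and an oxygen on a saturated carbon. Within the data shown here, no two measured compounds differ in one place only, so no measured step guides this change directly. Compound 2 offers the nearest hint, since it also has an open chain rather than an aromatic ring on that carbon and gives 21 mL.min-1.g-1 on a different core. The hint is weak, as compound 3 gives 43 mL.min-1.g-1 with an aromatic ring on that carbon. A modest rise in clearance is expected (an at least 1.3-fold higher number from compound 1 to compound 4 (0.12 log units; that floor lies within the scatter)), and the result could again be only a limit. Compound 4 is estimated at 16 mL.min-1.g-1 (expected range 9 mL.min-1.g-1 to 32 mL.min-1.g-1).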

Compound 4, intrinsic clearance in microsomes: 22 mL.min-1.g-1
Estimate against measurement, compound 4: 1.4-fold (0.14 log units) below; the range from low to high includes it.
By their numbers in this assay, from the lowest: compounds 2, 4 and 3 (each within the scatter of the next, the first and the last beyond it). At a limit, below all of these: compound 1.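

This step is the only comparison among the compounds shown in which a single place changes, the saturated chain carbon bound to a carbonyl carbon and an oxygen on a saturated carbon, while the core of compound 1 stays the same. In this assay, replacing 3-methylphenyl with neopentyl gives an at least 1.8-fold higher number from compound 1 to compound 4 (0.26 log units; that floor lies within the scatter), so the data show that this swap does not lower the number, although the smallest rise it allows remains within the usual scatter of repeated measurements. The true size of the rise remains unknown because one end of the step is a limit and not a number: the limit of < 12 mL.min-1.g-1 in this assay, at which 1 of the 4 values shown sits.

What the compounds shown leave open is whether the rise goes with losing the aromatic ring or with neopentyl itself, as only one aromatic ring and one open chain appear at this place on this core. A cyclohexyl group at the same carbon, keeping a ring but not an aromatic one, would help separate these two readings, and a shorter chain such as isopropyl would show how far the result depends on the size of the chain.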